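The source may hold more compounds than are shown below. What is called first, only, known or untested is meant among the compounds shown, and "the series" means these compounds.

The measured compounds in an assay for binding affinity to dual specificity mitogen-activated protein kinase kinase 4 (Homo sapiens), read by KINOMEscan, tested at 100 nM; a lower number here means a stronger effect, a higher number a weaker effect of the compound at the concentration tested:
Compound 1 `CCCS(=O)(=O)Nc1ccc(F)c(C(=O)c2n[nH]c3ncc(-c4ccccc4OC)cc23)c1F` gives 1.9%.
Compound 2 `CCCS(=O)(=O)Nc1ccc(F)c(C(=O)c2n[nH]c3ncc(-c4ccc(O)cc4)cc23)c1F` gives 0.75%.
Compound 3 `CCCS(=O)(=O)Nc1ccc(F)c(C(=O)c2n[nH]c3ncc(-c4ccccc4N)cc23)c1F` gives 23%.

Compound 3 stands highest of the three in this assay: compound 1 lies nearest, with a number 21.1 percentage points higher from compound 1 to compound 3 (beyond the scatter), and compound 2 furthest, with a number 22.3 percentage points higher from compound 2 to compound 3 (beyond the scatter). Compound 4 `CCCS(=O)(=O)Nc1ccc(F)c(C(=O)c2n[nH]c3ncc(-c4cccc(N)c4)cc23)c1F` differs from compound 3 in one place: 3-aminophenyl in place of 2-aminophenyl on an aromatic carbon. For the measured compounds named here, no measured step moves an amino group from one position of this phenyl ring to another. Going by the values given here, the steps that bear on the change are the two that bring in the 2-aminophenyl, a number 21.1 percentage points higher from compound 1 to compound 3 (beyond the scatter) and a number 22.3 percentage points higher from compound 2 to compound 3 (beyond the scatter), both modest rises, and the comparison of compound 1 with compound 2, a number 1.2 percentage points lower from compound 1 to compound 2 (within the scatter), which shows two other substituted phenyl groups giving similar low numbers. Because compound 3 alone stands at 23% while compound 1 stands at 1.9%, moving the amino to give 3-aminophenyl is expected to lower the number by a modest amount, with considerable uncertainty. Compound 4 is therefore estimated at 10%, in the range 1% to 40%, an expected step of a number 13 percentage points lower from compound 3 to compound 4 (beyond the scatter).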

Compound 4, a percentage reported as activity, at one concentration (the size of the read-out at that concentration, not a potency): 1.6%
Compound 4: the middle estimate sits 8.4 percentage points above what was measured; low and high end bracket the measured number.
By their numbers in this assay, from the lowest: compounds 2, 4 and 1 (each within the scatter of the next); then compound 3.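

In this assay, moving the amino group on the phenyl ring, with the same atoms joined differently, gives a number 21.4 percentage points lower from compound 3 to compound 4 (beyond the scatter), so an amino group as such does not carry the high number of compound 3; the 2-aminophenyl does, while the 2-methoxyphenyl of compound 1 shows that a group in that ring position need not raise it. The 3-aminophenyl joins the other two low compounds, with a number 0.9 percentage points higher from compound 2 to compound 4 (within the scatter) and a number 0.3 percentage points lower from compound 1 to compound 4 (within the scatter), which leaves compound 3 alone apart from the other three. Nothing given here accounts for the gap between the two aminophenyl groups.

The compounds shown leave open how a 4-aminophenyl, a 2-hydroxyphenyl or a 2-dimethylaminophenyl would read at this position. With a single tested concentration, they also leave compounds 1, 2 and 4 unranked.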